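This account rests on a few compounds, and the source may have more. Where it says the series, first, only, none or still open, it means among the compounds named here.

Working notes on the series in an assay on cells for inhibition of cytochrome P450 11B2, mitochondrial (Homo sapiens), read by HPLC, with a stated time of 90 min; on this read-out higher numbers stand for weaker inhibition and lower numbers for stronger inhibition. Compound 1 `Fc1ccc2nc(-c3cncnc3)n(C3CC3)c2c1` gives 40 nM. Within the data shown here, compound 2 `Fc1ccc2nc(-c3cccnn3)n(C3CC3)c2c1` gives 412 nM; the only single-point step measured is a 10-fold higher number from compound 1 to compound 2 (1.01 log units; beyond the scatter). Compound 3 `CC(C)c1ncncc1-c1nc2cc(F)c(F)cc2n1C1CC1` gives 5 nM, the lowest number of the three and well apart from both others. Compound 4 `Fc1cc2nc(-c3cncnc3NCCC(F)(F)F)n(C3CC3)c2cc1F` differs from compound 3 by (3,3,3-trifluoropropyl)amino in place of isopropyl on an aromatic carbon. Among the measured compounds shown here, no measured step touches this position; the one measured step concerns the six-membered ring itself rather than a substituent on it, so it gives no direct guide. Compound 4 is therefore expected to stay in the neighbourhood of compound 3, with a modest shift of a 3.0-fold higher number from compound 3 to compound 4 (0.48 log units; beyond the scatter) allowed either way, and its estimate is 15 nM with a range of 3 nM to 60 nM.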

Compound 4, half-maximal inhibitory concentration: 3 nM
Compound 4: middle estimate off by 5.0-fold (0.70 log units), on the high side, within the range that was stated.
By their numbers in this assay, from the lowest: compounds 4 and 3 (each within the scatter of the next); then compound 1; then compound 2.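

In this assay, (3,3,3-trifluoropropyl)amino in place of isopropyl gives a 1.7-fold lower number from compound 3 to compound 4 (0.22 log units; within the scatter), so on this aromatic carbon next to the ring nitrogen the two groups cannot be told apart by their numbers. The earlier step, a 10-fold higher number from compound 1 to compound 2 (1.01 log units; beyond the scatter), concerned the six-membered ring itself and gave no reading of a substituent here. No data on the cause of this result are at hand. From the compounds shown here alone, it remains open whether a simple methylamino group, a carboxylic acid or a longer fluorinated chain would also fit at this position. Going by these compounds, it also remains open whether the same exchange would read alike on the core of compound 1.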